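A few compounds are considered here, and "the series" means these few. Any claim that something is new, unique, unknown or untested is made for them only; others in the source may bear on it.

Measured compounds in a functional assay on HCT-116 cells (Homo sapiens) for inhibition, read by MTT assay, with a stated time of 48 h; a higher number here means a weaker inhibitor, a lower number a stronger inhibitor:
compound 1 `COc1ccc(-n2c(SCC(=O)c3ccc(OC)c(O)c3)nnc2-c2cc(OC)c(OC)c(OC)c2)cc1` — a limit only, > 60000 nM
compound 2 `COc1ccc(NC(=O)CSc2nnc(-c3cc(OC)c(OC)c(OC)c3)n2-c2ccc(OC)cc2)cc1` — a limit only, > 60000 nM
compound 3 `COc1cc(-c2nnc(SC)n2-c2ccc(N(C)C)cc2)cc(OC)c1OC` — a limit only, > 60000 nM

Every value recorded so far is a limit of the assay and not a number; all three compounds sit at the limit of > 60000 nM in this assay, at which 3 of the 3 values shown sit. Compound 3 therefore stands level with compound 1 and compound 2 as far as the numbers go, and no order among the three can be read. Within the data shown here, the single one-point comparison available, a step that the two limits leave unreadable from compound 1 to compound 2, is likewise unreadable, since both of its ends are limits.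

Compound 4 `COc1cc(-c2nnc(SCC(=O)Nc3ccc(Cl)cc3)n2-c2ccc(N(C)C)cc2)cc(OC)c1OC` differs from compound 3 by (4-chlorophenyl)carbamoyl in place of hydrogen on a saturated chain carbon bound to a sulfur. Compound 2 already carries a sulfanyl chain of this kind, ending in a carbonyl carbon that bears (4-methoxyphenyl)amino, and compound 2 too is reported only as a limit. Among the measured compounds shown here, nothing measured so far shows that building out the methylsulfanyl into a chain of this type brings the read-out off the limit. The expected step of a number no higher from compound 3 to compound 4 (the limit leaves the size open) is therefore none beyond the scatter, with the caveat that the starting point is itself only a limit. Compound 4 is estimated at 60000 nM, within 20000 nM to 120000 nM, and is expected most likely to be reported again as a limit.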

Compound 4, half-maximal inhibitory concentration: 39300 nM
Compound 4: middle estimate off by 1.5-fold (0.18 log units), on the high side, within the range that was stated.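

In this assay, (4-chlorophenyl)carbamoyl in place of hydrogen on a saturated chain carbon bound to a sulfur gives an at least 1.5-fold lower number from compound 3 to compound 4 (0.18 log units; that floor lies within the scatter). Going by these compounds, compound 3 is a limit only, so the true size of this step stays open and may exceed the floor printed with it. Compound 4 is the only compound in the series with a read-out that is a number, which shows that this place can carry such a chain and still give a measurable value, while the other compounds stay at a limit: the limit of > 60000 nM in this assay, at which 3 of the 4 values shown sit.

The step from compound 1 to compound 2 cannot be read, and compound 2 differs from compound 4 in more than one place, so the separate shares of the chlorine and the carbamoyl link in this number stay unsettled. Also open, on these data alone, is whether a carboxylic acid or a longer chain in place of the (4-chlorophenyl)carbamoyl, or a fluorine or a methyl in place of the chlorine, would move the read-out further from the limit.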